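This account rests on a few compounds, and the source may have more. Where it says the series, first, only, none or still open, it means among the compounds named here.

Among the measured compounds shown here, in a functional assay on G-361 cells (Homo sapiens) for antiproliferative activity, with a stated time of 72 h (on this read-out higher numbers stand for weaker inhibition and lower numbers for stronger inhibition), compound 1 `OC[C@H]1O[C@@H](n2cnc3c(NCc4ccc(Cl)cc4Cl)ncnc32)[C@H](O)[C@@H]1O` gives 128000 nM, the only single number reported across the three measured entries. Compound 2 `OC[C@H]1O[C@@H](n2cnc3c(NCc4cc(F)cc(F)c4)ncnc32)C(O)C1O` is reported in this assay only as a limit, > 166000 nM, which is the limit of > 166000 nM in this assay, at which 1 of the 3 values shown sits. For compound 3 `COc1ccc(CNc2ncnc3c2ncn3C2OC(CO)[C@@H](O)[C@H]2O)c(O)c1` this assay carries the entry "not determined" (no result reported), so no number is available for it. The unmeasured compound 4 `OC[C@H]1O[C@@H](n2cnc3c(NCc4cc(O)cc(O)c4)ncnc32)[C@H](O)[C@@H]1O` differs from compound 1 by 3,5-dihydroxyphenyl in place of 2,4-dichlorophenyl on a saturated chain carbon bound to a nitrogen on an aromatic ring. For the measured compounds named here, no measured pair in this set isolates such a change, so there is nothing to anchor its direction, and the weak activity of compound 1 leaves little room on either side. The step is expected to be a 1.2-fold higher number from compound 1 to compound 4 (0.07 log units; within the scatter), with no movement beyond the scatter foreseen. Compound 4 is estimated at 150000 nM, in the range 60000 nM to 400000 nM.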

Compound 4, half-maximal inhibitory concentration: > 166000 nM
Compound 4 was reported as a limit; the forecaster's own chance of this, stated with the estimate: 50%; at least 1.1-fold (0.04 log units) between middle value and limit.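

In this assay, among the compounds shown here, replacing 2,4-dichlorobenzyl with 3,5-dihydroxybenzyl gives the first step that can be read at this position: an at least 1.2-fold higher number from compound 1 to compound 4 (0.11 log units; that floor lies within the scatter). This is only a floor, but it gives no sign of stronger inhibition from the 3,5-dihydroxyphenyl group. The value of compound 4 is a limit and not a number, and that limit now holds more than one entry: the limit of > 166000 nM in this assay, at which 2 of the 4 values shown sit.

Going by these compounds, how far compound 4 lies past its limit remains open. So does whether an amine or a carboxylic acid in place of the 2,4-dichlorophenyl group would move the number beyond the scatter.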